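The source may hold more compounds than are shown below. What is called first, only, known or untested is meant among the compounds shown, and "the series" means these compounds.

Compound 1, `N=C(N)c1ccc2oc(-c3ccc(OCCCCOc4ccccc4)cc3)cc2c1`, carries a free amidine on one core and a phenoxy-capped chain of four carbons. Compound 2, `CC(C)NC(=N)c1ccc2oc(-c3ccc(OCCCCOc4ccccc4)cc3)cc2c1`, keeps that core and chain but bears isopropyl in place of hydrogen on an amine nitrogen. Compound 3, `N=C(N)c1ccc2cc(-c3ccc(OCCCCCCOc4ccccc4)cc3)oc2c1`, has a different core and a phenoxy-capped chain of six carbons; how the two cores differ is not broken down here. Compound 4, `CC(C)NC(=N)c1ccc2cc(-c3ccc(OCCCCCCOc4ccccc4)cc3)oc2c1`, stands to compound 3 as compound 2 stands to compound 1: isopropyl in place of hydrogen on an amine nitrogen, the same change at the same place, a nitrogen whose other neighbour is the carbon with a double bond to nitrogen.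

In an ADME assay on L6 cells (Rattus norvegicus) for cytotoxicity, read by resazurin assay, with a stated time of 70 h (on this read-out higher numbers stand for weaker inhibition and lower numbers for stronger inhibition), compound 1 gives 1300 nM. Compound 2 gives 6900 nM, and the step of a 5.3-fold higher number from compound 1 to compound 2 (0.72 log units; beyond the scatter) is beyond the scatter. Compound 3 gives 8000 nM; against compound 2 this lies within the scatter, while against compound 1 it is clearly a higher number.

Compound 4 is not yet measured in this assay. Among the measured compounds shown here, because the one measured instance of this change, a 5.3-fold higher number from compound 1 to compound 2 (0.72 log units; beyond the scatter), raised the number by a modest but real amount, the same direction is expected here, though it rests on a single pair and on a different core, so the spread is wide. Compound 4 is expected to show a step of a 4.4-fold higher number from compound 3 to compound 4 (0.64 log units; beyond the scatter) from compound 3. The estimate for compound 4 in this assay is 35000 nM, with a range from 12000 nM to 100000 nM.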

Compound 4, half-maximal inhibitory concentration: 4900 nM
Estimate against measurement, compound 4: 7.1-fold (0.85 log units) above, and the stated range ends above it.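

In this assay, isopropyl in place of hydrogen on an amine nitrogen gives a 1.6-fold lower number from compound 3 to compound 4 (0.21 log units; within the scatter), so compound 3 and compound 4 cannot be told apart, and the clear step seen with the same change on the core of compound 1 does not reappear; the two steps differ: the same change on two cores in this assay, a 5.3-fold higher number (0.72 log units; beyond the scatter) from compound 1 to compound 2 and a 1.6-fold lower number (0.21 log units; within the scatter) from compound 3 to compound 4, 8.7-fold (0.94 log units) apart, beyond the scatter of two such steps This shows that, within this series, the size of the step for this change cannot simply be carried from one of these pairs to the other, and that a result from one pair is a poor guide to the other. It does not show that the core is what sets the two steps apart, since the pairs differ in core and also in the length of the phenoxy-capped chain, and two pairs give no general rule for either.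

The compounds shown leave open how the change behaves with the shorter chain of compound 1 on the core of compound 3, or with the longer chain of compound 3 on the core of compound 1, which would separate core from chain. They also leave open whether a smaller group such as ethyl or a ring such as cyclopentyl on the same nitrogen would follow either step.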